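This account rests on a few compounds, and the source may have more. Where it says the series, first, only, none or still open, it means among the compounds named here.

Measured so far in an in vitro ADME assay on microsomes from liver (Mus musculus) for pharmacokinetics, read by LC-MS, with a stated time of 10 min, tested at 1 uM; a higher number here means faster removal of the compound, a lower number slower removal:
- compound 1 `CN1C[C@H](C(=O)Nc2ccc(Br)cc2)[C@@H](c2ccc(/C=C/C(=O)Nc3ccccc3N)cc2)C1` gives 16 mL/min/kg
- compound 2 `CN1C[C@H](C(=O)Nc2cccnc2)[C@@H](c2ccc(/C=C/C(=O)Nc3ccccc3N)cc2)C1` gives 41 mL/min/kg
- compound 3 `CN1C[C@H](C(=O)Nc2ccccn2)[C@@H](c2ccc(/C=C/C(=O)Nc3ccccc3N)cc2)C1` is not yet measured

For the measured compounds named here, of the two numbers in this assay, compound 2 has the higher, 41 mL/min/kg, and compound 1 is its only comparison. The next change, (pyridin-2-yl in place of pyridin-3-yl on an amide-type nitrogen), puts pyridin-2-yl in place of pyridin-3-yl on an amide-type nitrogen. Going by the values given here, only one measured step bears on this: a 2.6-fold higher number from compound 1 to compound 2 (0.41 log units; beyond the scatter), which is modest and beyond the scatter. That step replaces 4-bromophenyl at the same place, so it is only indirect evidence. Among the compounds with values here, no measured pair shows what this exchange of pyridinyl groups does, and no direction can be favoured. The expected change is therefore small, a 1.1-fold lower number from compound 2 to compound 3 (0.03 log units; within the scatter), and none beyond the scatter is expected. For compound 3 the estimated clearance is 38 mL/min/kg, with an expected range from 18 mL/min/kg to 80 mL/min/kg.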

Compound 3, clearance: 40 mL/min/kg
Compound 3: the middle estimate sits 1.1-fold (0.02 log units) below what was measured; the measured number falls inside the stated range.
By their numbers in this assay, from the lowest: compound 1; then compounds 3 and 2 (each within the scatter of the next).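

In this assay, the exchange of pyridin-3-yl for pyridin-2-yl on the amide-type nitrogen gives a 1.0-fold lower number from compound 2 to compound 3 (0.01 log units; within the scatter), so these two pyridinyl groups, made of the same atoms joined differently, cannot be told apart in this read-out. The step from 4-bromophenyl to pyridin-2-yl gives a 2.5-fold higher number from compound 1 to compound 3 (0.40 log units; beyond the scatter), so at this place both pyridinyl groups now stand apart from 4-bromophenyl, not just pyridin-3-yl. No supporting data are available to explain either result. From the compounds shown here alone, what a plain phenyl or a pyridin-4-yl group gives at this place remains open, so the gap to 4-bromophenyl cannot yet be assigned to the bromine or to the ring nitrogen. Also open, going by these compounds, is how a pyridinyl ring carrying an amine or a carboxylic acid would read.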